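From Methoxycarbonyl to Cyano on Compound 2

A few compounds are considered here, and "the series" means these few. Any claim that something is new, unique, unknown or untested is made for them only; others in the source may bear on it.

Of the compounds shown here, three sharing one core have been measured in a physicochemical assay for solubility, read by HPLC, using the shake flask method; a lower number here means a less soluble compound, a higher number a more soluble compound. Compound 1 `COC(=O)c1cccc(-c2cnc3[nH]cc(-c4cncnc4)c3c2)c1` gives 28600 nM, compound 2 `COC(=O)c1cccc(-c2cnc3[nH]cc(-c4cccnc4)c3c2)c1` gives 4300 nM, and compound 3 `COC(=O)c1cccc(-c2cnc3[nH]cc(-c4cccc(OC)c4)c3c2)c1` gives 2000 nM. Compound 2 therefore stands second highest of the three.

These compounds differ only in one aromatic group. Exchanging it produced a large step, a 14-fold lower number from compound 1 to compound 3 (1.16 log units; beyond the scatter), and two modest ones, a 6.7-fold lower number from compound 1 to compound 2 (0.82 log units; beyond the scatter) and a 2.2-fold lower number from compound 2 to compound 3 (0.33 log units; beyond the scatter). All three lie beyond the usual scatter.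

Compound 4 `N#Cc1cccc(-c2cnc3[nH]cc(-c4cccnc4)c3c2)c1` keeps the pyridin-3-yl group of compound 2 but carries cyano in place of methoxycarbonyl on an aromatic carbon. Among the measured compounds shown here, none of the measured steps touches this group, since methoxycarbonyl is present in compounds 1, 2 and 3. They show only how far one exchange elsewhere on the core can move the number, and they give no direction for this one.

The expectation therefore starts from compound 2 at 4300 nM, with no step beyond the scatter foreseen. The expected change is a 1.1-fold lower number from compound 2 to compound 4 (0.03 log units; within the scatter). The range stays wide, as a single exchange gave a 14-fold lower number from compound 1 to compound 3 (1.16 log units; beyond the scatter). For compound 4 the estimated value is 4000 nM, within an expected range from 1300 nM to 12000 nM.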

Compound 4, solubility: 5700 nM
Compound 4: middle estimate off by 1.4-fold (0.15 log units), on the low side; low and high end bracket the measured number.
By their numbers in this assay, from the lowest: compound 3; then compounds 2 and 4 (each within the scatter of the next); then compound 1.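

In this assay, among the compounds shown here, this is the first reading of the position that carries methoxycarbonyl, an aromatic carbon of a six-membered aromatic ring of carbon only; the earlier steps all exchanged the other aromatic group. With pyridin-3-yl held constant, putting cyano in place of methoxycarbonyl gives a 1.3-fold higher number from compound 2 to compound 4 (0.12 log units; within the scatter), a step within the scatter, so the two compounds cannot be told apart here, even though the group shrinks from 4 heavy atoms to 2 and swaps a double bond for a triple bond. No accompanying measurement bears on why the two groups read alike in this assay.

Cyano appears here only alongside pyridin-3-yl, so its effect alongside pyrimidin-5-yl or 3-methoxyphenyl remains an open question, and a single exchange cannot show how the position behaves in general. Also open, on these data alone, is whether a group of a different kind at this position, such as a carboxylic acid, an amine or a primary amide, would move the number beyond the scatter.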